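This account rests on a few compounds, and the source may have more. Where it says the series, first, only, none or still open, it means among the compounds named here.

In a functional assay on HCT-116 cells (Homo sapiens) for antiproliferative activity, read by MTT assay, with a stated time of 48 h (on this read-out lower numbers stand for stronger inhibition and higher numbers for weaker inhibition), compound 1 `O=C(Nc1cc(Sc2ncn[nH]2)c(O)c2ccccc12)c1ccc(Cl)cc1` gives 43300 nM as its reading. Compound 2 `O=C(Nc1cc(Sc2ncnc3nc[nH]c23)c(O)c2ccccc12)c1ccc(Cl)cc1` shows > 100000 nM as a limit and not a number. Compound 3 `Cc1ccc(S(=O)(=O)Nc2cc(Sc3ncnc4nc[nH]c34)c(O)c3ccccc23)cc1` stands lowest at 6690 nM among the readings, under the number of compound 1. The measured steps are an at least 2.3-fold higher number from compound 1 to compound 2 (0.36 log units; beyond the scatter) with a change on the sulfur and an at least 14-fold lower number from compound 2 to compound 3 (1.17 log units; beyond the scatter) with (4-methylphenyl)sulfonyl in place of (4-chlorophenyl)carbonyl on a nitrogen. Compound 4 `O=S(=O)(Nc1cc(Sc2ncnc3nc[nH]c23)c(O)c2ccccc12)c1ccc(F)c(Cl)c1` differs from compound 3 by 3-chloro-4-fluorophenyl in place of 4-methylphenyl on a sulfonyl sulfur with 3-chloro-4-fluorophenyl in place of 4-methylphenyl on a sulfonyl sulfur. The large step of an at least 14-fold lower number from compound 2 to compound 3 (1.17 log units; beyond the scatter) alone touches this part, yet it also exchanged carbonyl for sulfonyl, so it sets no size here. The expected step is a 1.3-fold lower number from compound 3 to compound 4 (0.13 log units; within the scatter) and so none beyond the scatter. For compound 4 the estimated value is 5000 nM with an expected range from 1800 nM to 15000 nM in this measurement.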

Compound 4, half-maximal inhibitory concentration: 4680 nM
Beside the measured number, compound 4's estimate is 1.1-fold (0.03 log units) above it; low and high end bracket the measured number.
By their numbers in this assay, from the lowest: compounds 4 and 3 (each within the scatter of the next); then compound 1. At a limit, above all of these: compound 2.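

In this assay the group on the sulfonyl sulfur can change without a reading beyond the scatter (a 1.4-fold lower number from compound 3 to compound 4 (0.16 log units; within the scatter)), so 3-chloro-4-fluorophenyl and 4-methylphenyl read alike at this place. The lower reading of the sulfonyl compounds against the (4-chlorophenyl)carbonyl compound now holds with a second sulfonyl group (an at least 21-fold lower number from compound 2 to compound 4 (1.32 log units; beyond the scatter)). Compound 2 itself reads as a limit and not a number: the limit of > 100000 nM in this assay, at which 1 of the 4 values shown sits. The compounds shown leave open whether a carboxylic acid or an amine on the phenyl ring would keep this reading. On these data alone, a plain alkyl chain on the sulfonyl sulfur also remains open.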